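Swapping sulfamoylmethyl for methylsulfamoyl in a flat series

The source may report more compounds than this note shows. Statements on the series, on what has been measured and on what is new or still open speak of the compounds shown alone.

Of the compounds shown here, three sharing one core have been measured in a functional assay on MC-38 cells (Mus musculus) for antiproliferative activity (a higher number here means a weaker inhibitor, a lower number a stronger inhibitor), and form the whole of the evidence so far. Compound 1 `NC(=O)c1ccc(S(=O)(=O)Nc2cccc3c(Cl)c[nH]c23)cc1` gives 0.19 ug/mL and compound 2 `Nc1ccc(S(=O)(=O)Nc2cccc3c(Cl)c[nH]c23)cc1` gives 0.23 ug/mL on this read-out. Compound 3 `NS(=O)(=O)Cc1ccc(S(=O)(=O)Nc2cccc3c(Cl)c[nH]c23)cc1` gives 0.12 ug/mL and stands within the scatter of both others, which leaves no order among the three.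

Compound 4 `CNS(=O)(=O)c1ccc(S(=O)(=O)Nc2cccc3c(Cl)c[nH]c23)cc1` has methylsulfamoyl in place of sulfamoylmethyl on an aromatic carbon, para to a large group. The difference is counted as methylsulfamoyl in place of sulfamoylmethyl on an aromatic carbon and the two structures hold the same atoms, joined differently. Three measured steps exchange the group at this same place, and a 1.2-fold higher number from compound 1 to compound 2 (0.08 log units; within the scatter) as well as a 1.6-fold lower number from compound 1 to compound 3 (0.20 log units; within the scatter) and a 1.9-fold lower number from compound 2 to compound 3 (0.28 log units; within the scatter) all stay within the scatter. For the measured compounds named here, no measured compound carries methylsulfamoyl, so the group itself remains untested. No step beyond the scatter is therefore expected in this assay for this exchange. The expected step is a 1.3-fold higher number from compound 3 to compound 4 (0.12 log units; within the scatter) and it lies within the scatter. Compound 4 is estimated at 0.16 ug/mL with an expected range from 0.08 ug/mL to 0.33 ug/mL on this evidence.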

Compound 4, half-maximal inhibitory concentration: 0.24 ug/mL
Beside the measured number, compound 4's estimate is 1.5-fold (0.18 log units) below it, and the stated range covers the measured number.
By their numbers in this assay, from the lowest: compounds 3, 1, 2 and 4 (each within the scatter of the next).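

In this assay, for the compounds shown here, moving the same atoms from sulfamoylmethyl to methylsulfamoyl gives a 2.0-fold higher number from compound 3 to compound 4 (0.30 log units; within the scatter), the widest step so far, yet it is still printed as within the scatter, so this exchange of connectivity at the position para to a large group cannot be read as a real change. The other two steps to the new compound, a 1.0-fold higher number from compound 2 to compound 4 (0.02 log units; within the scatter) and a 1.3-fold higher number from compound 1 to compound 4 (0.10 log units; within the scatter), are also within the scatter, so a fourth group at this aromatic carbon leaves the series flat, with no order among compounds 1, 2, 3 and 4. No supporting data on any property of these compounds is available to interpret even the widest of these steps.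

From the compounds shown here alone, what remains open is whether any group at this position can move the number beyond the scatter, for example a carboxylic acid, a dimethylsulfamoyl or a longer chain such as sulfamoylethyl. Also open, going by these compounds, is whether the shared core is equally tolerant elsewhere, for example with bromo in place of its chloro.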